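Swapping chloro for cyclopropylamino in compound 2

A few compounds are considered here, and "the series" means these few. Any claim that something is new, unique, unknown or untested is made for them only; others in the source may bear on it.

compound 1 `Cn1ncc2c1[C@@H](CO[Si](c1ccccc1)(c1ccccc1)C(C)(C)C)C[C@H]2Cn1cnc2c(O)ncnc21`: 3.2 ug/mL
compound 2 `OC[C@H]1C[C@@H](Cn2cnc3c(Cl)ncnc32)c2ccccc21`: 24 ug/mL
compound 3 `Cn1ncc2c1[C@H](Cn1cnc3c(Cl)nc(N)nc31)C[C@@H]2CO`: 3.2 ug/mL

In a functional assay on CCRF-CEM cells (Homo sapiens) (a lower number here means a stronger inhibitor, a higher number a weaker inhibitor), compound 2 has the highest number of the three (24 ug/mL) and is therefore the weakest inhibitor here. Compound 1 and compound 3 both lie lower, beyond the scatter.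

Compound 4 `OC[C@H]1C[C@@H](Cn2cnc3c(NC4CC4)ncnc32)c2ccccc21` keeps the core of compound 2 but carries cyclopropylamino in place of chloro on an aromatic carbon. Within the data shown here, no measured pair shows this swap alone, so the forecast is loose, and no shift beyond the scatter is expected in this assay. The expected step is a 1.3-fold higher number from compound 2 to compound 4 (0.10 log units; within the scatter) and it would leave the number close to where it stands. The estimate for compound 4 is 30 ug/mL (range 8 ug/mL to 100 ug/mL).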

Compound 4, half-maximal inhibitory concentration: 24 ug/mL
Estimate against measurement, compound 4: 1.3-fold (0.10 log units) above, and the stated range covers the measured number.
By their numbers in this assay, from the lowest: compounds 1 and 3 (each within the scatter of the next); then compounds 2 and 4 (each within the scatter of the next).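

In this assay, cyclopropylamino in place of chloro on this aromatic carbon gives no change at the digits printed from compound 2 to compound 4 (within the scatter) as its result. At this position, then, a single chlorine can give way to a larger group that brings a three-membered ring and a hydrogen-bond donor, with no shift beyond the usual scatter. No supporting measurement is available to explain this result.

As far as these compounds go, whether a methoxy group or a dimethylamino group at this position would give a similar number remains open. So does whether a longer chain on the nitrogen would.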